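Aryl swap on the saturated chain carbon: outlook for compound 3

The source may report more compounds than this note shows. Statements on the series, on what has been measured and on what is new or still open speak of the compounds shown alone.

Measured so far:
- compound 1 `Cc1ccc(Cn2cc(CSC(=S)N3CCN(C(=O)OCc4ccccc4)CC3)nn2)cc1`; in a functional assay on PC-3 cells (Homo sapiens) for inhibition, read by MTT assay, with a stated time of 72 h (on this read-out higher numbers stand for weaker inhibition and lower numbers for stronger inhibition), compound 1 gives > 128000 nM, a limit of the assay and not a number.
- compound 2 `COc1cc(Cn2cc(CSC(=S)N3CCN(C(=O)OCc4ccccc4)CC3)nn2)cc(OC)c1OC`; in this assay compound 2 gives > 128000 nM, likewise a limit rather than a number.

Compound 2 therefore stands only at a limit, with no readable number beside it. Among the measured compounds shown here, the single comparison between measured compounds, a step that the two limits leave unreadable from compound 1 to compound 2, is left unreadable, because of the limit of > 128000 nM in this assay, at which 2 of the 2 values shown sit. For the measured compounds named here, no step of known size exists.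

Compound 3 `O=C(OCc1ccccc1)N1CCN(C(=S)SCc2cn(Cc3ccccc3Cl)nn2)CC1` is the next member. It differs from compound 2 by 2-chlorophenyl in place of 3,4,5-trimethoxyphenyl on a saturated chain carbon bound to an aromatic nitrogen. Going by the values given here, the only measured step that touches this position is the one from compound 1 to compound 2, and its size cannot be read, so neither direction nor magnitude can be carried over to compound 3. The two limits give no ground to expect a reading away from the limit.

Compound 3 is therefore expected to sit at about 150000 nM in this assay, within a range of 40000 nM to 500000 nM. The expected step is a step that the limit leaves unreadable from compound 2 to compound 3, none beyond the scatter, most likely reported again only as a limit.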

Compound 3, half-maximal inhibitory concentration: > 128000 nM
Compound 3 was reported as a limit; the forecaster's own chance of this, stated with the estimate: 75%; the middle value does not contradict the limit.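

In this assay no new step can be read among compound 1, compound 2 and compound 3, because each is reported only as a limit and not as a number: the limit of > 128000 nM in this assay, at which 3 of the 3 values shown sit.

The compounds shown leave open whether 4-methylphenyl, 3,4,5-trimethoxyphenyl and 2-chlorophenyl on a saturated chain carbon bound to an aromatic nitrogen differ at all in inhibition.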